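Nitro for Methoxy: Expected Cytotoxicity of Compound 4

The compounds below may be only part of what the source reports. "The series", "measured", "known", "first", "only" and "open" are said of these compounds alone.

In an ADME assay on MT4 cells (Homo sapiens) for cytotoxicity, read by MTT assay (on this read-out lower numbers stand for higher toxicity in this test and higher numbers for lower toxicity in this test), three compounds have been examined so far. Compound 1, `COc1ccc(CSc2nc(Cc3cccc(Br)c3)c(C)c(=O)[nH]2)cc1`, gives only a limit in this assay, > 290000 nM. Compound 2, `Cc1c(Cc2cccc(Br)c2)nc(SCc2ccc([N+](=O)[O-])cc2)[nH]c1=O`, likewise returns only a limit, > 280000 nM. Compound 3, `CCc1c(Cc2c(Cl)cccc2Cl)nc(SCc2ccc(OC)cc2)[nH]c1=O`, also reaches no number but a limit, > 287000 nM. Compound 1 and compound 2 differ in a single place: nitro in place of methoxy on an aromatic carbon. The step that the two limits leave unreadable from compound 1 to compound 2 cannot be read because the limit of > 290000 nM in this assay, at which 1 of the 3 values shown sits, and the limit of > 280000 nM in this assay, at which 1 of the 3 values shown sits, both sit at the edge of what this assay reports. Compound 4, `CCc1c(Cc2c(Cl)cccc2Cl)nc(SCc2ccc([N+](=O)[O-])cc2)[nH]c1=O`, is the unmeasured partner of compound 3 and carries the same change: nitro in place of methoxy on an aromatic carbon. The difference between the core of compound 1 and the core of compound 3 is not broken down here. With the measured pair giving no readable direction, the expected step is a step that the limit leaves unreadable from compound 3 to compound 4, a guess that rests on compound 3 standing at the limit of > 287000 nM in this assay, at which 1 of the 3 values shown sits, in this assay. Compound 4 is therefore estimated at 290000 nM, most probably reported once more as a limit rather than a number.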

Compound 4, half-maximal cytotoxic concentration: > 278000 nM
Compound 4: a limit, no number; the forecaster's own chance of this, stated with the estimate: 85%; the middle value is on the limit's open side.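

Compound 4, like compound 3, returns only a limit in this assay, and the step between the two cannot be read. The compounds shown leave open whether nitro in place of methoxy on an aromatic carbon moves this read-out in either direction, on the core of compound 1 or on the core of compound 3.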